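The source may hold more compounds than are shown below. What is called first, only, known or untested is meant among the compounds shown, and "the series" means these compounds.

Measured compounds:
compound 1 `O=C(COc1ccc2cc(/C=C3/SC(=O)NC3=O)ccc2c1)Nc1ccccn1` in an assay on isolated protein for inhibition of histone deacetylase 8 (Homo sapiens), with a stated time of 1 h; on this read-out lower numbers stand for stronger inhibition and higher numbers for weaker inhibition: > 50000 nM
compound 2 `O=C(COc1ccc2cc(/C=C3/SC(=O)NC3=O)ccc2c1)Nc1ccc(Cl)c(Cl)c1` in this assay: > 50000 nM

Compound 1 stands only at a limit of this assay, not at a number; > 50000 nM is the value reported for compound 1. Compound 2 likewise gives only a limit in this assay. The step that the two limits leave unreadable from compound 1 to compound 2 therefore cannot be sized, because the limit of > 50000 nM in this assay, at which 2 of the 2 values shown sit, is where both values sit.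

Compound 3 `Cc1cccc(NC(=O)COc2ccc3cc(/C=C4/SC(=O)NC4=O)ccc3c2)n1` differs from compound 1 by methyl in place of hydrogen on an aromatic carbon, a change of one carbon on the pyridin-2-yl group of the amide.

Going by the values given here, no measured step bears directly on this change; the only step is unreadable. Given that compound 1 sits at the limit, compound 3 is expected also to sit at or beyond that limit in this assay, with a step that the limit leaves unreadable from compound 1 to compound 3 most likely unreadable. The estimate for compound 3 is 100000 nM, between 30000 nM and 500000 nM.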

Compound 3, half-maximal inhibitory concentration: 7500 nM
Estimate against measurement, compound 3: 13-fold (1.12 log units) above; the whole stated range lies above it.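

In this assay, going by these compounds alone, the position next to the ring nitrogen of the pyridin-2-yl group is the first place where a change yields a readable number: methyl in place of hydrogen there gives an at least 6.6-fold lower number from compound 1 to compound 3 (0.82 log units; beyond the scatter). A single added carbon is therefore enough to bring this amide series off the limit, and 6-methylpyridin-2-yl in place of 3,4-dichlorophenyl gives an at least 6.6-fold lower number from compound 2 to compound 3 (0.82 log units; beyond the scatter). The step between compound 1 and compound 2 still cannot be read, because neither compound has a number: the limit of > 50000 nM in this assay, at which 2 of the 3 values shown sit.

From the compounds shown here alone, the full size of both readable steps stays open, since each starts from a limit. Also open, going by these compounds, is whether ethyl, methoxy or an amine at the same position would match methyl, and whether methyl elsewhere on the pyridine ring would do the same.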